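This account rests on a few compounds, and the source may have more. Where it says the series, first, only, none or still open, it means among the compounds named here.

Compound 1 `O=C(NCc1ccc(CNS(=O)(=O)c2ccc(CN3CCCC3)cc2)cc1)c1ccc(F)cc1` is the standout of the three measured compounds: in an assay on MDA-MB-231 cells for binding affinity to C-X-C chemokine receptor type 4 (Homo sapiens), read by fluorescence and microscopy, with stated times of 10 min and 30 min (on this read-out higher numbers stand for an effect only at larger amounts of compound and lower numbers for an effect already at smaller amounts), compound 1 gives 1 nM, the lowest number shown. Compound 2 `O=C(NCc1ccc(CNS(=O)(=O)c2cccnc2)cc1)c1ccc(F)cc1` gives 1000 nM and compound 3 `O=C(NCc1ccc(CNS(=O)(=O)c2ccccc2Cl)cc1)c1ccc(F)cc1` gives 1000 nM, both far from compound 1. Neither compound 2 nor compound 3 carries the (pyrrolidin-1-yl)methyl group found in compound 1, and swapping the aryl ring on the sulfonyl sulfur between them made no difference, no change at the digits printed from compound 2 to compound 3 (within the scatter). Compound 4 `O=C(NCc1ccc(CNS(=O)(=O)c2ccc(-c3ccc(F)cc3)cc2)cc1)c1ccc(F)cc1` differs from compound 1 by 4-fluorophenyl in place of (pyrrolidin-1-yl)methyl on an aromatic carbon. Among the measured compounds shown here, no measured pair shows exactly this change, but the gap between compound 1 and compounds 2 and 3 suggests that losing the (pyrrolidin-1-yl)methyl group matters greatly. The expected step is therefore a large rise, a 600-fold higher number from compound 1 to compound 4 (2.78 log units; beyond the scatter). Compound 4 is estimated at 600 nM, within 60 nM to 6000 nM.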

Compound 4, effective concentration (reported as EC, without a stated level of effect): 100 nM
Beside the measured number, compound 4's estimate is 6.0-fold (0.78 log units) above it, within the range that was stated.
By their numbers in this assay, from the lowest: compound 1; then compound 4; then compounds 2 and 3 (each within the scatter of the next).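

Here, on an aromatic carbon, 4-fluorophenyl in place of (pyrrolidin-1-yl)methyl gives a 100-fold higher number from compound 1 to compound 4 (2.00 log units; beyond the scatter) in this assay with the rest of the structure unchanged. Unlike the earlier compounds, this pair isolates that single replacement, and compound 4 keeps a large ring-bearing group at this position. No measurement here accounts for the size of this step. Still open, as far as these compounds go, is whether another amine at this position, such as (piperidin-1-yl)methyl or (dimethylamino)methyl, would give a number close to that of compound 1. A carboxylic acid at the same position would test a different kind of group.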